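The source may report more compounds than this note shows. Statements on the series, on what has been measured and on what is new or still open speak of the compounds shown alone.

Compound 1 `FC(F)(F)c1ccc(Nc2ncnc3sc(Nc4c(Cl)cccc4Cl)nc23)cc1`: 3 nM
Compound 2 `FC(F)(F)c1ccc(Nc2ncnc3sc(Nc4ccccc4Cl)nc23)cc1`: 32 nM
Compound 3 `CS(=O)(=O)c1ccccc1Nc1nc2c(Nc3ccc(C(F)(F)F)cc3)ncnc2s1`: 221 nM

All three were tested in a functional assay on HEK293 cells for antagonist activity at transient receptor potential cation channel subfamily V member 1 (Rattus norvegicus), read by calcium flux; a higher number here means a weaker inhibitor, a lower number a stronger inhibitor. Among them compound 1 stands lowest: the nearest is compound 2, at an 11-fold higher number from compound 1 to compound 2 (1.03 log units; beyond the scatter), and the furthest is compound 3, at a 74-fold higher number from compound 1 to compound 3 (1.87 log units; beyond the scatter). Between the other two the gap is a 6.9-fold higher number from compound 2 to compound 3 (0.84 log units; beyond the scatter). Both measured steps change the 2,6-dichlorophenyl group or its chloro substituents, leaving the trifluoromethyl-bearing ring untouched.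

Compound 4 `CSc1ccc(Nc2ncnc3sc(Nc4c(Cl)cccc4Cl)nc23)cc1` has not yet been tested. It differs from compound 1 elsewhere: methylsulfanyl in place of trifluoromethyl on an aromatic carbon. Among the compounds with values here, none of the measured steps touches that ring, so none bears directly on this change; the large effects seen on the 2,6-dichlorophenyl side say nothing about what a swap on the other ring will do. The expectation therefore rests on compound 1 alone, with a wide range in both directions. For compound 4 the step expected in this assay is a 2.7-fold higher number from compound 1 to compound 4 (0.43 log units; beyond the scatter). Compound 4 is estimated at 8 nM, most likely between 2 nM and 40 nM.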

Compound 4, half-maximal inhibitory concentration: 12 nM
Beside the measured number, compound 4's estimate is 1.5-fold (0.18 log units) below it; the measured number falls inside the stated range.
By their numbers in this assay, from the lowest: compound 1; then compound 4; then compound 2; then compound 3.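

This is the first change shown on the ring that carries trifluoromethyl. In this assay, putting methylsulfanyl in place of trifluoromethyl on this aromatic carbon, para to a large group, gives a 4.0-fold higher number from compound 1 to compound 4 (0.60 log units; beyond the scatter). The step is beyond the scatter but modest, so this position accepts a group with a sulfur atom and no fluorine while the compound remains a nanomolar inhibitor, with trifluoromethyl the better of these two groups; nothing available here explains the difference.

Two groups are too few to show a trend at this position, and a nitrile, an amine or a carboxylic acid there could behave quite differently. From the compounds shown here alone, it also remains open whether removing a chloro from the 2,6-dichlorophenyl group would cost as much with methylsulfanyl on the other ring.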